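Cytotoxicity notes: amine swap on the coumarin-chromone series

The source may report more compounds than this note shows. Statements on the series, on what has been measured and on what is new or still open speak of the compounds shown alone.

Of the compounds shown here, three have been measured in an ADME assay on MT4 cells (Homo sapiens) for cytotoxicity, read by MTT assay, with a stated time of 96 h; a lower number here means that less compound is tolerated, a higher number that more compound is tolerated. Compound 1 `COc1ccc2c(=O)c(Cc3c(OC(C)=O)ccc4c(C)cc(=O)oc34)c(N(C)C)oc2c1` gives 42000 nM. Compound 3 `CCC(=O)Oc1ccc2ccc(=O)oc2c1Cc1c[nH]c2ccccc12` gives 65000 nM. For compound 2 `COc1ccc2c(=O)c(Cc3c(OC(C)=O)ccc4ccc(=O)oc34)c(N3CCCC3)oc2c1` only a limit was reported, > 100000 nM, which is the ceiling of this assay; this is noted as the limit of > 100000 nM in this assay, at which 1 of the 3 values shown sits. No two of these three compounds differ in a single place, so no measured step can be drawn between them and no cause for any difference can be given.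

Compound 4 `COc1ccc2c(=O)c(Cc3c(OC(C)=O)ccc4ccc(=O)oc34)c(N(C)C)oc2c1` has not yet been measured. It departs from compound 2 by dimethylamino in place of pyrrolidin-1-yl on an aromatic carbon. With no measured step of this kind in the series, the size of the change in this assay can only be guessed; a small downward drift is expected, with compound 1 at 42000 nM as the nearest dimethylamino analogue. The expected step of an at least 1.5-fold lower number from compound 2 to compound 4 (0.18 log units; that floor lies within the scatter) is therefore modest and may still end in a limit. Compound 4 is estimated at 65000 nM, with a range from 30000 nM to 150000 nM.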

Compound 4, half-maximal cytotoxic concentration: 26000 nM
Compound 4: the middle estimate sits 2.5-fold (0.40 log units) above what was measured, outside the stated range (below it).
By their numbers in this assay, from the lowest: compounds 4, 1 and 3 (each within the scatter of the next, the first and the last beyond it). At a limit, above all of these: compound 2.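

In this assay, for the compounds shown here, dimethylamino in place of pyrrolidin-1-yl on the aromatic carbon next to the ring oxygen gives the first measured step at this position, an at least 3.8-fold lower number from compound 2 to compound 4 (0.58 log units; beyond the scatter). Compound 2 is held at a limit and not a number, so this step gives only a floor: the limit of > 100000 nM in this assay, at which 1 of the 4 values shown sits. The second change, hydrogen in place of methyl on an aromatic carbon, gives a 1.6-fold lower number from compound 1 to compound 4 (0.21 log units; within the scatter), so this methyl is not resolved as a change in this read-out.

On these data alone, whether the step follows the ring of pyrrolidin-1-yl or its count of heavy atoms remains open, and an amine such as diethylamino or morpholin-4-yl on this carbon would bear on that. As far as these compounds go, the true size of the step also stays open while compound 2 remains a limit.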